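Compound 3: bromo in place of amino

The compounds below may be only part of what the source reports. "The series", "measured", "known", "first", "only" and "open" are said of these compounds alone.

In a functional assay on CEM-SS cells (Homo sapiens) for cytotoxicity (on this read-out higher numbers stand for weaker inhibition and lower numbers for stronger inhibition), compound 1 `COc1ccc(Cn2c(N)nc3cc(Cl)c(Cl)cc32)cc1` gives 27000 nM. In the same assay, compound 2 `Cc1ccc(Cn2c(N)nc3cc(Cl)c(Cl)cc32)cc1` gives 40000 nM. These are the only two measured numbers in the series, and they lie within the scatter of each other, so compound 1 has no separate standing on the numbers shown.

Compound 3 `COc1ccc(Cn2c(Br)nc3cc(Cl)c(Cl)cc32)cc1` keeps the core of compound 1 and the methoxy group, with one change: bromo in place of amino on an aromatic carbon. Within the data shown here, the only measured step, a 1.5-fold higher number from compound 1 to compound 2 (0.17 log units; within the scatter), is methyl in place of methoxy on an aromatic carbon. It does not touch the amino group and bears on the new change only indirectly. Among the measured compounds shown here, no measured compound lacks the amino group, so the data give no direction for this replacement. On this evidence, no step beyond the scatter is expected in this assay, though the uncertainty is wide. The expected size of the move is a 1.5-fold higher number from compound 1 to compound 3 (0.17 log units; within the scatter). For compound 3 the estimated value is 40000 nM, with an expected range from 12000 nM to 100000 nM.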

Compound 3, half-maximal inhibitory concentration: 60000 nM
Compound 3: middle estimate off by 1.5-fold (0.18 log units), on the low side, within the range that was stated.
By their numbers in this assay, from the lowest: compounds 1, 2 and 3 (each within the scatter of the next, the first and the last beyond it).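

Among these compounds, the place on an aromatic carbon between two ring nitrogen atoms responds to change in this assay: bromo in place of amino gives a 2.2-fold higher number from compound 1 to compound 3 (0.35 log units; beyond the scatter), a modest move but the only step printed as beyond the scatter. Among the compounds shown here, the earlier step, a 1.5-fold higher number from compound 1 to compound 2 (0.17 log units; within the scatter), altered the methoxy group and left this place untouched, so compound 3 is the first reading of what happens when the amino group leaves, and the direction with bromo is towards a higher number, meaning weaker inhibition on this read-out. Amino counts as a hydrogen-bond donor and acceptor while bromo counts as neither, but nothing measured links that difference to the move, and no available evidence accounts for it.

Still open, from the compounds shown here alone, is whether chloro, hydroxyl or methylamino at this place would read closer to compound 1 or to compound 3, and so whether the move is specific to bromo or follows from losing the amino group. Also open, going by these compounds, is whether bromo in place of amino gives a similar step when methyl stands in place of methoxy on the benzyl part.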